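Dropping a fluoro from a diaryl ether in a cytotoxicity screen

The source may hold more compounds than are shown below. What is called first, only, known or untested is meant among the compounds shown, and "the series" means these compounds.

Compound 1, `COc1cc2[nH]c(C)c(-c3ccc(Oc4ccc(OC(F)(F)F)c(F)c4)cc3)c(=O)c2cc1Cl`: in an ADME assay on HepG2 cells (Homo sapiens) for cytotoxicity, read by resazurin assay, with a stated time of 24 h (on this read-out higher numbers stand for weaker inhibition and lower numbers for stronger inhibition), compound 1 gives > 10000 nM, a limit of the assay rather than a number.
Compound 2, `Cc1[nH]c2ccccc2c(=O)c1-c1ccc(Oc2ccc(OC(F)(F)F)cc2)nc1`: in this assay compound 2 gives > 10000 nM, again a limit.
Compound 3, `COc1cc2[nH]c(C)c(-c3ccc(Oc4ccc(OC(F)(F)F)cc4)nc3)c(=O)c2cc1Cl`: in this assay compound 3 gives > 10000 nM, also a limit.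

Compound 1 therefore stands nowhere in particular among the numbers shown, since there are no numbers: every value rests at the limit of > 10000 nM in this assay, at which 3 of the 3 values shown sit. Compounds 2 and 3 share the pyridyl ether and differ in the core substitution, while compound 1 carries the fluoro on the trifluoromethoxyphenyl ring; none of the three is separated from the others by anything the assay could resolve.

Compound 4, `COc1cc2[nH]c(C)c(-c3ccc(Oc4ccc(OC(F)(F)F)cc4)cc3)c(=O)c2cc1Cl`, is not yet measured. It differs from compound 1 by hydrogen in place of fluoro on an aromatic carbon. Within the data shown here, with no step between measured compounds to lean on, and all three values at the limit, the expectation for this assay is no step beyond the scatter in either direction.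

The estimate for compound 4 is 15000 nM, with a range from 8000 nM to 40000 nM. That estimate means a step that the limit leaves unreadable from compound 1 to compound 4, which is expected to sit within the scatter, and the result is expected to be reported, like that of compound 1, as a limit.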

Compound 4, half-maximal inhibitory concentration: > 10000 nM
Compound 4: a limit, no number; the forecaster's own chance of this, stated with the estimate: 85%; the middle value does not contradict the limit.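

In this assay, among these compounds, compound 4, like compound 1, gives a limit rather than a number, so no step between the two can be read for hydrogen in place of fluoro on an aromatic carbon: the limit of > 10000 nM in this assay, at which 4 of the 4 values shown sit. The compounds shown leave open how far each lies from that limit and which change to the structure, if any, would yield a measurable value.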